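Methylphenyl for chlorophenyl on the oxadiazole-linked aryl group

The source may report more compounds than this note shows. Statements on the series, on what has been measured and on what is new or still open speak of the compounds shown alone.

Three compounds of the series carry the same core and differ only in the aryl group on the five-membered ring. In a functional assay on HCT-116 cells (Homo sapiens) for inhibition, read by MTT assay, with a stated time of 24 h, tested at 5 uM (a lower number here means less inhibition of growth, a higher number more inhibition of growth at the concentration tested), compound 1 `CS(=O)(=O)c1ccc(-c2cnc3[nH]cc(-c4nnc(-c5ccccc5)o4)c(=O)c3c2)cc1` gives 8.6%, compound 2 `CS(=O)(=O)c1ccc(-c2cnc3[nH]cc(-c4nnc(-c5ccccn5)o4)c(=O)c3c2)cc1` gives 11.3%, and compound 3 `CS(=O)(=O)c1ccc(-c2cnc3[nH]cc(-c4nnc(-c5ccc(Cl)cc5)o4)c(=O)c3c2)cc1` gives 16.4%. Compound 3 holds the highest of the three numbers, but its steps from the others, a number 7.8 percentage points higher from compound 1 to compound 3 (within the scatter) and a number 5.1 percentage points higher from compound 2 to compound 3 (within the scatter), both lie within the scatter, as does a number 2.7 percentage points higher from compound 1 to compound 2 (within the scatter); on this assay the three compounds are not separated.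

Compound 4 `Cc1cccc(-c2nnc(-c3c[nH]c4ncc(-c5ccc(S(C)(=O)=O)cc5)cc4c3=O)o2)c1` follows from compound 3 by the change (3-methylphenyl in place of 4-chlorophenyl on an aromatic carbon). Among the measured compounds shown here, the steps that bear on this exchange are those that already vary the same aryl group: the chloro for hydrogen step from compound 1 to compound 3 and the aryl exchange from compound 2 to compound 3, neither of which moved this assay beyond the scatter. A 3-methylphenyl group has not been measured in the series, so nothing points to a larger effect than those seen. No step beyond the scatter is therefore expected in this assay for compound 4, with a number 4.4 percentage points lower from compound 3 to compound 4 (within the scatter) as the expected step, and compound 4 is estimated at 12%, within a range from 3% to 22%.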

Compound 4, percent growth inhibition at one concentration: 20.4%
The estimate for compound 4 lay 8.4 percentage points below the measured number, and the stated range covers the measured number.
By their numbers in this assay, from the lowest: compounds 1, 2, 3 and 4 (each within the scatter of the next, the first and the last beyond it).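

With methyl in place of hydrogen on the phenyl group, the aryl position gives in this assay its first step that clears the scatter, a number 11.8 percentage points higher from compound 1 to compound 4 (beyond the scatter), though the size of this step is only modest. The exchanges against the two other aryl groups do not separate the new group: 4-chlorophenyl gives way to 3-methylphenyl with a number 4 percentage points higher from compound 3 to compound 4 (within the scatter) and pyridin-2-yl gives way to it with a number 9.1 percentage points higher from compound 2 to compound 4 (within the scatter), so only the unsubstituted phenyl group stands apart from 3-methylphenyl, and the chloro and methyl variants remain together. Among the compounds shown here, no measured property of these groups is available to account for the single step beyond the scatter.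

Open, from the compounds shown here alone, is whether an ethyl or a methoxy group in place of the methyl of 3-methylphenyl would hold, extend or lose this modest step, and whether an amine or a carboxylic acid on the same phenyl ring would do the same. All of these numbers also rest on one tested concentration, which leaves open how the compounds would compare across a range of concentrations.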